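The compounds below may be only part of what the source reports. "The series", "measured", "known", "first", "only" and "open" are said of these compounds alone.

Measured compounds in a functional assay on PC-12 cells (Rattus norvegicus) for inhibition, read by sulforhodamine B assay; a lower number here means a stronger inhibitor, a higher number a weaker inhibitor:
Compound 1 `CCC(C)(C)Oc1ccc(CC2SC(=O)NC2=O)cc1` gives 23000 nM.
Compound 2 `CCC(C)(C)Oc1ccc(/C=C2\SC(=O)NC2=O)cc1` gives 15000 nM.
Compound 3 `CC(C)COc1ccc(CC2SC(=O)NC2=O)cc1` gives 25000 nM.

The three compounds share a phenyl ether bearing a thiazolidinedione, and their values in this assay all sit within the usual scatter of one another. Compound 1 and compound 3 differ in one place only: isobutyl in place of 1,1-dimethylpropyl on an oxygen on an aromatic ring. That step, a 1.1-fold higher number from compound 1 to compound 3 (0.04 log units; within the scatter), is within the scatter, so the shorter chain is not seen to matter here.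

Compound 2 differs from compound 1 in its core; the difference between the two cores is not broken down here. Compound 4 `CC(C)COc1ccc(/C=C2\SC(=O)NC2=O)cc1` has not yet been measured. It is related to compound 2 by the same change that relates compound 3 to compound 1: isobutyl in place of 1,1-dimethylpropyl on an oxygen on an aromatic ring. Going by the values given here, since the one measured instance of this change, a 1.1-fold higher number from compound 1 to compound 3 (0.04 log units; within the scatter), stays within the scatter, compound 4 is expected to sit close to compound 2, with an expected step of a 1.1-fold higher number from compound 2 to compound 4 (0.05 log units; within the scatter). The estimate for compound 4 in this assay is 17000 nM, with a plausible range from 8000 nM to 36000 nM.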

Compound 4, half-maximal inhibitory concentration in the PC-12 assay: 16000 nM
Estimate against measurement, compound 4: 1.1-fold (0.03 log units) above; the measured number falls inside the stated range.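

In the PC-12 assay, the new step, a 1.1-fold higher number from compound 2 to compound 4 (0.03 log units; within the scatter), stays within the scatter and matches the earlier step on the other core: the same change on two cores in the PC-12 assay, a 1.1-fold higher number (0.04 log units; within the scatter) from compound 1 to compound 3 and a 1.1-fold higher number (0.03 log units; within the scatter) from compound 2 to compound 4, 1.0-fold (0.01 log units) apart, within the scatter of two such steps Across these two pairs, then, isobutyl in place of 1,1-dimethylpropyl leaves the number in the PC-12 assay unmoved on either core, but two pairs cannot establish a rule for the series, and a change with no visible effect on either core says little about how the cores would respond to a change that does have one. In a physicochemical assay for lipophilicity (a lower number here means a more polar compound, a higher number a more lipophilic compound), compound 2 gives 3.49 and compound 4 gives 3.09. The same change does register in the physicochemical assay, though this is shown on the core of compound 2 alone, so it cannot be said to carry over to the core of compound 1: the measured partition coefficient of compound 2, 3.49, and of compound 4, 3.09, a number 0.40 log units lower (beyond the scatter)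

The compounds shown leave open whether any other group on an oxygen on an aromatic ring, such as a longer chain, an amine or a carboxylic acid, would move the number in the PC-12 assay beyond the scatter. They also leave open whether such a step would be the same size on both cores.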